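The source may report more compounds than this note shows. Statements on the series, on what has been measured and on what is new or still open speak of the compounds shown alone.

Measured compounds:
compound 1, `CCCCc1cc2c(=O)c(CC)c[nH]c2cc1OCCOc1ccccc1`: 360 nM
compound 2, `COC(=O)c1c[nH]c2ccc(OCCCc3ccccc3)cc2c1=O`: 17100 nM

In an ADME assay on J774 cells (Mus musculus) for cytotoxicity (on this read-out lower numbers stand for an effect already at smaller amounts and higher numbers for an effect only at larger amounts of compound), compound 1 gives 360 nM, the lowest of the two numbers measured. Compound 2, in this assay, gives 17100 nM, a number far higher than that of compound 1 and well beyond the usual scatter. Among the measured compounds shown here, the two compounds differ in several places at once, so their values show only that compound 1 acts at the smaller amount.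

Compound 3, `CCCCc1cc2c(=O)c(I)c[nH]c2cc1OCCOc1ccccc1`, has not been measured. It is compound 1 with one change: iodo in place of ethyl on an aromatic carbon. For the measured compounds named here, no measured pair shows this same change, so there is no direct guide to its effect. The expected step from compound 1 to compound 3 is a 1.4-fold higher number from compound 1 to compound 3 (0.14 log units; within the scatter), a small shift upward that stays within the scatter. Compound 3 is therefore estimated at 500 nM, with a range from 120 nM to 2500 nM.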

Compound 3, half-maximal effective concentration: > 10000 nM
Compound 3: a limit, no number; the forecaster's own chance of this, stated with the estimate: 5%; middle value at least 20-fold (1.30 log units) away from the limit.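

In this assay putting iodo in place of ethyl on this aromatic carbon, two atoms from the ring nitrogen, gives an at least 27-fold higher number from compound 1 to compound 3 (1.44 log units; beyond the scatter) with this one change alone. The two compounds measured earlier differ in several places at once, whereas this pair shows that a single position on the shared core can move the read-out well beyond the scatter. For compound 3 the result is a limit and not a number, so the step gives only a lower bound on the true size of the shift: the limit of > 10000 nM in this assay, at which 1 of the 3 values shown sits.

Going by these compounds, only ethyl and iodo can be compared at this carbon, so it remains open whether the shift is particular to iodo. A chloro group, a methyl group or a carboxylic acid at the same place, or the same swap on a different side chain, would help to settle this.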